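Swapping the piperidine acyl group for a 4-chlorobenzyl

A few compounds are considered here, and "the series" means these few. Any claim that something is new, unique, unknown or untested is made for them only; others in the source may bear on it.

compound 1 `O=C(CCCC1CCN(C(=O)CCc2ccccc2)CC1)c1ncco1` 22 nM
compound 2 `O=C(CCCC1CCN(C(=O)CCC2CCCCC2)CC1)c1ncco1` 3 nM
compound 3 `CC(C)(C)CC(=O)N1CCC(CCCC(=O)c2ncco2)CC1` 90 nM

In an assay on isolated protein for inhibition of Fatty-acid amide hydrolase 1 (Homo sapiens) (a higher number here means a weaker inhibitor, a lower number a stronger inhibitor), compound 3 gives the highest number of the three, standing a 4.1-fold higher number from compound 1 to compound 3 (0.61 log units; beyond the scatter) and a 30-fold higher number from compound 2 to compound 3 (1.48 log units; beyond the scatter). Compound 4 `O=C(CCCC1CCN(Cc2ccc(Cl)cc2)CC1)c1ncco1` differs from it by 4-chlorobenzyl in place of neopentylcarbonyl on an amine nitrogen in a ring. Among the measured compounds shown here, no measured step bears on this change directly: both a 4.1-fold higher number from compound 1 to compound 3 (0.61 log units; beyond the scatter) and a 30-fold higher number from compound 2 to compound 3 (1.48 log units; beyond the scatter) alter only the group bound to a carbonyl that stays in place, whereas here the carbonyl itself leaves. Those steps show that the group on the amine nitrogen moves the number by modest to large amounts, and an aromatic ring was tolerated in compound 1. A modest rise is therefore expected, a 1.7-fold higher number from compound 3 to compound 4 (0.22 log units; within the scatter), giving compound 4 an estimated 150 nM with a range of 25 nM to 900 nM.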

Compound 4, half-maximal inhibitory concentration: 66 nM
Beside the measured number, compound 4's estimate is 2.3-fold (0.36 log units) above it; the measured number falls inside the stated range.
By their numbers in this assay, from the lowest: compound 2; then compound 1; then compounds 4 and 3 (each within the scatter of the next).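

The step of a 1.4-fold lower number from compound 3 to compound 4 (0.13 log units; within the scatter) shows that in this assay the amine nitrogen of this ring can lose its carbonyl entirely, and the number stays within the scatter when 4-chlorobenzyl enters in place of neopentylcarbonyl. The carbonyl on this nitrogen is therefore not required for inhibition at this level in this pair, although the swap also replaces the rest of the group. Nothing available explains this result.

The compounds shown leave open what the chlorine contributes, as a plain benzyl would test. They also leave open whether cyclohexylmethyl bound directly to this nitrogen would behave like the acyl group of compound 2.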